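Swapping an aromatic amide group for a short diol chain

The compounds below may be only part of what the source reports. "The series", "measured", "known", "first", "only" and "open" are said of these compounds alone.

Compound 1 `CCn1c(C(=O)NCCN)ccc1C(CC)(CC)c1ccc(OCCC(O)(CC)CC)c(C)c1` carries a 2-aminoethyl group on its amide nitrogen, and in a functional assay on HepG2 cells (Homo sapiens) for antiproliferative activity, read by MTT assay, with a stated time of 48 h (a lower number here means a stronger inhibitor, a higher number a weaker inhibitor), compound 1 gives 1590 nM. Compound 2 `CCOc1ccc(NC(=O)c2ccc(C(CC)(CC)c3ccc(OCCC(O)(CC)CC)c(C)c3)n2CC)cc1` has a 4-ethoxyphenyl group there instead. In this assay compound 2 reaches only the limit of the measurement, > 50000 nM. Going by the values given here, the single measured step, an at least 31-fold higher number from compound 1 to compound 2 (1.49 log units; beyond the scatter), thus leaves compound 2 as the weaker of the two, sitting at the limit of > 50000 nM in this assay, at which 1 of the 2 values shown sits. Compound 3 `CCn1c(C(=O)NC(CO)CCO)ccc1C(CC)(CC)c1ccc(OCCC(O)(CC)CC)c(C)c1` is the next change: 3-hydroxy-1-(hydroxymethyl)propyl in place of 4-ethoxyphenyl on an amide-type nitrogen. This removes the aromatic group whose arrival went with that large loss and installs a short open chain bearing hydroxyl groups, an open chain as in compound 1. Among the compounds with values here, the step of an at least 31-fold higher number from compound 1 to compound 2 (1.49 log units; beyond the scatter) is the only guide, and much of it is expected to be undone, so the estimated step is an at least 16-fold lower number from compound 2 to compound 3 (1.22 log units; beyond the scatter). Compound 3 is therefore expected to give 3000 nM, with a range from 800 nM to 15000 nM.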

Compound 3, half-maximal inhibitory concentration: 24800 nM
Estimate against measurement, compound 3: 8.3-fold (0.92 log units) below; the whole stated range lies below it.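

The 3-hydroxy-1-(hydroxymethyl)propyl group does not restore what the 2-aminoethyl group gives on this amide-type nitrogen: a 16-fold higher number from compound 1 to compound 3 (1.19 log units; beyond the scatter). An open chain in place of the 4-ethoxyphenyl group is therefore not enough on its own, since compound 1 and compound 3 both carry one and still differ clearly in this assay. The gain over the aromatic group can be read only as a floor, an at least 2.0-fold lower number from compound 2 to compound 3 (0.30 log units; that floor lies within the scatter), and compound 2 stands at a limit of the assay, not at a number: the limit of > 50000 nM in this assay, at which 1 of the 3 values shown sits.

As far as these compounds go, it remains open whether the amine of compound 1 or some other feature of its chain accounts for this gap. A 2-hydroxyethyl group or a longer chain ending in an amine would help to separate these two readings.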